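Replacing a sulfonamide tail with a carboxamide tail

This account rests on a few compounds, and the source may have more. Where it says the series, first, only, none or still open, it means among the compounds named here.

Going by the values given here, compound 1 `O=S(=O)(NCCCNc1nccc(-c2c(-c3cccc(F)c3)nc3sccn23)n1)c1ccc(Br)cc1` is measured in a functional assay on SK-MEL-28 cells (Homo sapiens) for cytotoxicity, read by MTT assay (a lower number here means a stronger inhibitor, a higher number a weaker inhibitor), at 9400 nM, the second highest of the three numbers seen, with no step to any other compound beyond the scatter. Compound 2 `Cc1ccc(S(=O)(=O)NCCCNc2nccc(-c3c(-c4cccc(F)c4)nc4sccn34)n2)cc1` gives 9500 nM, and compound 3 `O=S(=O)(NCCCNc1nccc(-c2c(-c3cccc(F)c3)nc3sccn23)n1)c1cccc(F)c1` gives 8550 nM. The step of a 1.0-fold higher number from compound 1 to compound 2 (0.00 log units; within the scatter) and the step of a 1.1-fold lower number from compound 1 to compound 3 (0.04 log units; within the scatter) both show that swapping the group on the aromatic ring of the tail leaves the number essentially unchanged. Compound 4 `O=C(NCCNc1nccc(-c2c(-c3cccc(F)c3)nc3sccn23)n1)c1ccc(Cl)cc1` differs from compound 1 by ((4-chlorophenyl)carbonyl)amino in place of (((4-bromophenyl)sulfonyl)amino)methyl on a saturated chain carbon, two bonds along the chain from a nitrogen on an aromatic ring. Among the compounds with values here, no measured step covers a swap of the sulfonyl for a carbonyl, so the expectation rests on the absence of any movement so far. Compound 4 is therefore expected to show a 1.0-fold lower number from compound 1 to compound 4 (0.02 log units; within the scatter), giving an estimate of 9000 nM with a range from 3000 nM to 27000 nM.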

Compound 4, half-maximal inhibitory concentration: 8160 nM
For compound 4 the middle estimate is 1.1-fold (0.04 log units) above the measured one, within the range that was stated.
By their numbers in this assay, from the lowest: compounds 4, 3, 1 and 2 (each within the scatter of the next).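

Earlier steps changed only the aromatic ring of the tail, whereas here the link itself changes, with a carbonyl replacing the sulfonyl on a shorter chain. In this assay the number still stays within the scatter (a 1.2-fold lower number from compound 1 to compound 4 (0.06 log units; within the scatter)), (a 1.0-fold lower number from compound 3 to compound 4 (0.02 log units; within the scatter)) and (a 1.2-fold lower number from compound 2 to compound 4 (0.07 log units; within the scatter)), so among these compounds the sulfonyl link is not needed to keep the number at this level. Nothing here offers an explanation for this flatness.

The carbonyl and the shorter chain enter together, so their separate contributions cannot be told apart. On these data alone, whether an amine or a carboxylic acid at the end of the chain would move the number remains open.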